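One Core, Two Amides, and One Untested Change

The source may hold more compounds than are shown below. What is called first, only, known or untested is meant among the compounds shown, and "the series" means these compounds.

compound 1 `COc1cc(F)c(NC(=O)c2ccncc2OC)cc1Nc1nccc(-c2cn(C)c3ccccc23)n1` — 3430 nM
compound 2 `COc1cc(F)c(NC(=O)c2ncccn2)cc1Nc1nccc(-c2cn(C)c3ccccc23)n1` — 8400 nM

For the measured compounds named here, in a functional assay on A549 cells (Homo sapiens) for antiproliferative activity, read by MTT assay, with a stated time of 72 h (on this read-out lower numbers stand for stronger inhibition and higher numbers for weaker inhibition), compound 1 gives 3430 nM, the lower of the two numbers measured so far. Compound 2 gives 8400 nM. Going by the values given here, the single measured step, a 2.4-fold higher number from compound 1 to compound 2 (0.39 log units; beyond the scatter), concerns only the group on the carbonyl carbon of the amide and leaves the rest of the shared core untouched.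

Compound 3 `COc1cc(N(C)CCN(C)C)c(NC(=O)c2ccncc2OC)cc1Nc1nccc(-c2cn(C)c3ccccc23)n1` differs from compound 1 at a different place: (2-(dimethylamino)ethyl)(methyl)amino in place of fluoro on an aromatic carbon. Among the compounds with values here, no measured step touches this aromatic carbon, so the step from compound 1 to compound 2 offers no direct guide, and the data give no basis for predicting a shift beyond the scatter in either direction. The expected step is therefore a 1.6-fold lower number from compound 1 to compound 3 (0.19 log units; within the scatter), kept within the usual scatter. Compound 3 is estimated at 2200 nM, with a wide range from 300 nM to 12000 nM reflecting the lack of a precedent.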

Compound 3, half-maximal inhibitory concentration: 2690 nM
The estimate for compound 3 lay 1.2-fold (0.09 log units) below the measured number; measured number inside the range.
By their numbers in this assay, from the lowest: compounds 3 and 1 (each within the scatter of the next); then compound 2.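

For the compounds shown here, at this aromatic carbon, this assay records a 1.3-fold lower number from compound 1 to compound 3 (0.11 log units; within the scatter) as fluoro gives way to (2-(dimethylamino)ethyl)(methyl)amino, the first measured step at this position. The exchange replaces 1 heavy atom with 7 heavy atoms and adds 2 hydrogen-bond acceptors, yet the numbers for compound 1 and compound 3 remain within the usual scatter of each other, so this larger chain leaves no measurable mark on this read-out. No available evidence bears on why this is so. The compounds shown leave open how a smaller group on the same carbon, such as methoxy or a plain dimethylamino group, or a ring amine such as morpholine or piperazine, would read here. They also leave open whether this chain would give a similar step on the core of compound 2, with its pyrimidin-2-yl amide.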